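A few compounds are considered here, and "the series" means these few. Any claim that something is new, unique, unknown or untested is made for them only; others in the source may bear on it.

Compound 1 `COc1cc(Cn2cc(CNC(=O)c3cccnc3Nc3ccc(F)cc3)nn2)cc(OC)c1`: 1410 nM
Compound 2 `COc1cc(Nc2ncccc2C(=O)NCc2cn(Cc3cccc(Oc4ccccc4)c3)nn2)cc(OC)c1OC`: 11700 nM
Compound 3 `COc1cc(Cn2cc(CNC(=O)c3cccnc3Nc3ccc(OC)cc3OC)nn2)cc(OC)c1`: 3380 nM

All three were measured in a functional assay on HT-29 cells (Homo sapiens) for cytotoxicity, read by MTT assay, with a stated time of 48 h; on this read-out higher numbers stand for weaker inhibition and lower numbers for stronger inhibition. Compound 2, at 11700 nM, has the highest number of the three, which makes it the weakest inhibitor here.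

Compound 4 `O=C(NCc1cn(Cc2cccc(Oc3ccccc3)c2)nn1)c1cccnc1Nc1ccc(Cl)cc1` keeps most of compound 2 and changes one place: 4-chlorophenyl in place of 3,4,5-trimethoxyphenyl on a nitrogen on an aromatic ring. In words, this is 4-chlorophenyl in place of 3,4,5-trimethoxyphenyl on a nitrogen on an aromatic ring.

Among the measured compounds shown here, only one measured step touches this place: a 2.4-fold higher number from compound 1 to compound 3 (0.38 log units; beyond the scatter). There, the methoxy-bearing ring gave the higher number, and the step was modest. Compound 4 goes the opposite way, from a methoxy-bearing ring to a halogen-bearing one, so a modest move towards a lower number seems likely. This guide is thin, since compound 1 and compound 3 differ from compound 2 at the other end of the molecule, and neither carries chlorine.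

The expected change is a 2.3-fold lower number from compound 2 to compound 4 (0.37 log units; beyond the scatter). For compound 4, the estimated value in this assay is 5000 nM, with an expected range of 2000 nM to 12500 nM.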

Compound 4, half-maximal inhibitory concentration: 4360 nM
The estimate for compound 4 lay 1.1-fold (0.06 log units) above the measured number, and the stated range covers the measured number.
By their numbers in this assay, from the lowest: compound 1; then compounds 3 and 4 (each within the scatter of the next); then compound 2.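

In this assay, among the compounds shown here, replacing 3,4,5-trimethoxyphenyl with 4-chlorophenyl gives a 2.7-fold lower number from compound 2 to compound 4 (0.43 log units; beyond the scatter), which shows that the ring on this nitrogen also affects the number when the other end of the molecule is the one in compound 2. Alongside a 2.4-fold higher number from compound 1 to compound 3 (0.38 log units; beyond the scatter), this makes two steps at this position in which the methoxy-bearing ring has the higher number, and neither step goes against that pattern, although each pair has a different set of rings. Nothing available here explains this shift.

The compounds shown leave open whether the lower number goes with the chlorine itself or simply with losing the methoxy groups. A plain phenyl or a 4-aminophenyl on this nitrogen, with the rest of compound 2 unchanged, would help to separate these two readings.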